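One added methyl on a weakly active amide chain

The compounds below may be only part of what the source reports. "The series", "measured", "known", "first", "only" and "open" are said of these compounds alone.

In a functional assay on K562 cells (Homo sapiens) for antiproliferative activity (a higher number here means a weaker inhibitor, a lower number a stronger inhibitor), compound 1 (`CC#CC(=O)N[C@@H]1[C@H]2OC(C)(C)O[C@H]2O[C@@H]1[C@H]1COC(C)(C)O1`) gives 500000 nM as its value. Compound 2 (`CCC(=O)N[C@@H]1[C@H]2OC(C)(C)O[C@H]2O[C@@H]1[C@H](O)CO`) gives 30000000 nM and so holds the higher of the two numbers, which makes it the weaker inhibitor of the pair by a gap beyond the scatter.

Among the compounds with values here, compound 3 (`CCCC(=O)N[C@@H]1[C@H]2OC(C)(C)O[C@H]2O[C@@H]1[C@H](O)CO`) has no measurement yet. It differs from compound 2 by one change (methyl in place of hydrogen on a saturated chain carbon, two bonds along the chain from a carbonyl carbon) with methyl in place of hydrogen on a saturated chain carbon, two bonds along the chain from a carbonyl carbon, which turns propanoyl into propylcarbonyl. Within the data shown here, no measured pair shows a change of this kind, and compound 1 differs from compound 2 in more than one place. With compound 2 at 30000000 nM as the only close reference, a small step towards a lower number is expected in this assay and it may well stay within the scatter. The estimated step (a 2.5-fold lower number from compound 2 to compound 3 (0.40 log units; beyond the scatter)) is therefore modest. Compound 3 is expected at 12000000 nM with an estimated range of 3000000 nM to 40000000 nM for repeat measurements.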

Compound 3, half-maximal inhibitory concentration: 500000 nM
For compound 3 the middle estimate is 24-fold (1.38 log units) above the measured one; the measured number lies below the stated range.
By their numbers in this assay, from the lowest: compounds 1 and 3 (each within the scatter of the next); then compound 2.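

In this assay, this place on the chain proves far from silent: methyl in place of hydrogen on a saturated chain carbon, two bonds along the chain from a carbonyl carbon, gives a 60-fold lower number from compound 2 to compound 3 (1.78 log units; beyond the scatter) as its step, and it does so with 1 heavy atom entering and no ring. The earlier compounds shown here could not show this, since compound 1 and compound 2 differ in more than one place and so gave no reading of any single change on the amide chain. The turn from propanoyl to propylcarbonyl is therefore the first single change shown to move the number by a large margin, although nothing measured here accounts for the size of the step.

As far as these compounds go, what remains open is whether the trend continues along the chain, as a longer chain such as butyl or pentyl could show, or whether an amine or a carboxylic acid at the end of the chain would be tolerated at all. This single pair also leaves open whether the same methyl would give a step of similar size on a compound carrying the other end of compound 1.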